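This account rests on a few compounds, and the source may have more. Where it says the series, first, only, none or still open, it means among the compounds named here.

Measured so far:
compound 1, `CN1C[C@H](C(=O)Nc2cccc(F)c2)[C@@H](c2ccc(/C=C/C(=O)Nc3ccccc3N)cc2)C1`, 6 mL/min/kg
compound 2, `CN1C[C@H](C(=O)Nc2ccc(F)c(Br)c2)[C@@H](c2ccc(/C=C/C(=O)Nc3ccccc3N)cc2)C1`, 15 mL/min/kg
compound 3, `Cc1cc(NC(=O)[C@H]2CN(C)C[C@@H]2c2ccc(/C=C/C(=O)Nc3ccccc3N)cc2)ccc1Cl`, 15 mL/min/kg

In an in vitro ADME assay on microsomes from liver (Homo sapiens) for pharmacokinetics, read by LC-MS, with a stated time of 10 min, tested at 1 uM (on this read-out lower numbers stand for slow clearance and higher numbers for fast clearance), compound 1 gives the lowest number of the three. The step of a 2.5-fold higher number from compound 1 to compound 2 (0.40 log units; beyond the scatter) and the step of a 2.5-fold higher number from compound 1 to compound 3 (0.40 log units; beyond the scatter) are both of the same modest size and both point upward, while no change at the digits printed from compound 2 to compound 3 (within the scatter) shows no change at the digits printed. Compound 4, `CN1C[C@H](C(=O)N2CCCCC2)[C@@H](c2ccc(/C=C/C(=O)Nc3ccccc3N)cc2)C1`, is the compound not yet measured. It differs from compound 1 in one place: piperidin-1-yl in place of (3-fluorophenyl)amino on a carbonyl carbon. The two measured steps from compound 1 each swapped one substituted phenyl for another on the amide-type nitrogen, whereas the step to compound 4 removes the aryl amine altogether and puts a saturated ring in its place, so neither measured step bears on it directly; they only show that compound 1 sits at the low end of this small set and that a change at this position has so far moved the number upward by a modest amount. On that slender basis compound 4 is expected to come out near compound 1 or somewhat above it, with the step of a 1.7-fold higher number from compound 1 to compound 4 (0.22 log units; within the scatter) regarded as uncertain in size. The estimate for compound 4 in this assay is 10 mL/min/kg, within a range from 4 mL/min/kg to 25 mL/min/kg.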

Compound 4, clearance: 9 mL/min/kg
Beside the measured number, compound 4's estimate is 1.1-fold (0.05 log units) above it; the range from low to high includes it.
By their numbers in this assay, from the lowest: compounds 1, 4, 2 and 3 (each within the scatter of the next, the first and the last beyond it).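

In this assay, within the data shown here, the carbonyl carbon carrying this group proves able to take a saturated ring in place of a substituted phenylamino group, since piperidin-1-yl in place of (3-fluorophenyl)amino gives a 1.5-fold higher number from compound 1 to compound 4 (0.18 log units; within the scatter) and leaves the number in the range of the earlier compounds. The same kind of exchange gives a 1.7-fold lower number from compound 3 to compound 4 (0.22 log units; within the scatter) and also a 1.7-fold lower number from compound 2 to compound 4 (0.22 log units; within the scatter), so compound 4 cannot be told apart from any of the three compounds with a phenylamino group, even though their own substituted phenyl groups had separated compound 1 from compound 2 and compound 3. Nothing shown here accounts for these numbers.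

From the compounds shown here alone, whether other groups on this carbonyl carbon would stay in the same range remains open, for example pyrrolidine, morpholine, an open-chain dimethylamino group, or a piperidine ring bearing a hydroxyl or methyl group. It is also open whether any such group would give a number clearly separated from that of compound 4, since the one saturated ring shown here sits within the scatter of all three other compounds.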